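The compounds below may be only part of what the source reports. "The series", "measured", "known", "first", "only" and "open" are said of these compounds alone.

Measured compounds in an ADME assay on L02 cells (Homo sapiens) for cytotoxicity, read by MTT assay; on this read-out lower numbers stand for stronger inhibition and higher numbers for weaker inhibition:
compound 1 `C#CCOc1cc(/C=C/C(=O)c2ccc(OC)c3c2OC(C)(C)C=C3)ccc1OC` — reported as a limit, > 10000 nM
compound 2 `C=CCOc1cc(/C=C/C(=O)c2ccc(OC)c3c2OC(C)(C)C=C3)ccc1OC` — reported as a limit, > 20000 nM
compound 3 `COc1ccc(/C=C/C(=O)c2ccc(OC)c3c2OC(C)(C)C=C3)cc1OC(=O)CCl` — reported as a limit, > 10000 nM

Compound 1 stands at the limit of > 10000 nM in this assay, at which 2 of the 3 values shown sit; this is a limit of the assay and not a number. Compound 2 sits at the limit of > 20000 nM in this assay, at which 1 of the 3 values shown sits, likewise a limit. Compound 3 is also given only as a limit. The measured steps a step that the two limits leave unreadable from compound 1 to compound 2, a step that the two limits leave unreadable from compound 1 to compound 3 and a step that the two limits leave unreadable from compound 2 to compound 3 each join two limits, so none of them yields a readable size or direction.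

Compound 4 `COc1ccc(/C=C/C(=O)c2ccc(OC)c3c2OC(C)(C)C=C3)cc1OS(=O)(=O)c1ccc(C)cc1` differs from compound 1 by (4-methylphenyl)sulfonyl in place of propargyl on an oxygen on an aromatic ring. The oxygen on the aromatic ring carrying this group is the same place that was varied among compounds 1, 2 and 3, and those variations left every value at a limit. The measured steps therefore give no size and no direction for the new change. In this assay the expected step is a step that the limit leaves unreadable from compound 1 to compound 4, taken as none beyond the scatter. Compound 4 is expected to give about 15000 nM in this assay, within 5000 nM to 60000 nM, and most probably to be reported again as a limit rather than a number.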

Compound 4, half-maximal inhibitory concentration: > 10000 nM
Compound 4 ended at the assay's limit (the forecaster's own chance of this, stated with the estimate: 85%); the middle value lies beyond the limit too.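

In this assay compound 4 gives > 10000 nM, which is a limit and not a number, so its steps from compound 1, compound 2 and compound 3 cannot be read. The compounds shown leave open whether any group on this oxygen on an aromatic ring gives a numerical value in this assay.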